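The source may report more compounds than this note shows. Statements on the series, on what has been measured and on what is new or still open speak of the compounds shown alone.

Among the measured compounds shown here, compound 2 `O=c1cc(CSc2cccs2)c2ccc(O)cc2o1` gives the lowest of the two numbers in an assay on HeLa cells for inhibition of 17-beta-hydroxysteroid dehydrogenase type 3 (Homo sapiens) (a lower number here means a stronger inhibitor, a higher number a weaker inhibitor), at 420 nM; its only neighbour, compound 1 `COCc1cc(=O)oc2cc(O)ccc12`, gives 5000 nM. That pair differs by a 12-fold lower number from compound 1 to compound 2 (1.08 log units; beyond the scatter). Compound 3 `O=c1cc(CSc2nccs2)c2ccc(O)cc2o1` carries 1,3-thiazol-2-yl in place of thiophen-2-yl on a sulfur. No measured step alters the ring on the sulfur: the single step shown exchanges the whole sulfanyl group for methoxy and so does not bear on this change. Compound 3 is therefore expected to move by only a 1.2-fold higher number from compound 2 to compound 3 (0.08 log units; within the scatter), within the scatter, at an estimated 500 nM (range 180 nM to 1500 nM).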

Compound 3, half-maximal inhibitory concentration: 10 nM
Compound 3: the middle estimate sits 50-fold (1.70 log units) above what was measured; the whole stated range lies above it.
By their numbers in this assay, from the lowest: compound 3; then compound 2; then compound 1.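

In this assay, placing 1,3-thiazol-2-yl in place of thiophen-2-yl on the sulfur gives a 42-fold lower number from compound 2 to compound 3 (1.62 log units; beyond the scatter), showing that the ring on the sulfur, untouched by the earlier step, strongly affects the number at this position. Relative to methoxy, the whole (1,3-thiazol-2-yl)sulfanyl group gives a 500-fold lower number from compound 1 to compound 3 (2.70 log units; beyond the scatter), a larger step than the thiophene-bearing sulfanyl group gave. Nothing available explains this gain. Going by these compounds, it remains open whether a pyridin-2-yl or phenyl ring on the sulfur would match the thiazole, and how an amine or methyl group on the thiazole ring would change the number.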